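Sulfonamide nitrogen substituent in a dichlorobenzamide series

A few compounds are considered here, and "the series" means these few. Any claim that something is new, unique, unknown or untested is made for them only; others in the source may bear on it.

Working notes on compound 2 and the step to compound 4. In a functional assay on HEK293 cells for agonist activity at probable G-protein coupled receptor 27 (Homo sapiens), read by a luciferase reporter and beta-arrestin recruitment, with a stated time of 10 min (on this read-out lower numbers stand for an effect already at smaller amounts and higher numbers for an effect only at larger amounts of compound), compound 2 `O=C(Nc1ccc(S(=O)(=O)NCc2ccccc2)cc1)c1ccc(Cl)cc1Cl` reaches only a limit, > 100000 nM, and not a number. Compound 1 `O=C(Nc1cccc(S(=O)(=O)Nc2ccccc2)c1)c1ccc(Cl)cc1Cl` likewise gives only a limit in this assay, > 100000 nM. For the measured compounds named here, compound 3 `Cc1cc(Cl)ccc1C(=O)Nc1ccc(S(=O)(=O)Nc2ccccc2)cc1` is the one member with a number in this assay, 912 nM. Compound 2 therefore sits together with compound 1 at the limit of > 100000 nM in this assay, at which 2 of the 3 values shown sit, the weak end of what has been seen, while compound 3 stands apart from both with a measurable value. No pair among these three differs in only one place, so no single step has been measured.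

Compound 4 `O=C(Nc1ccc(S(=O)(=O)Nc2cccc(Cl)c2)cc1)c1ccc(Cl)cc1Cl` is not yet measured. It differs from compound 2 by 3-chlorophenyl in place of benzyl on a sulfonamide nitrogen; cut one bond further out, the difference reads benzylamino to (3-chlorophenyl)amino. Compound 3, which also carries no benzyl on its sulfonamide nitrogen, gives 912 nM in this assay. Compound 2 starts from a limit. Going by the values given here, a gain well beyond the scatter is expected, an at least 33-fold lower number from compound 2 to compound 4 (1.52 log units; beyond the scatter), though no measured step anchors its size. Compound 4 is estimated at 3000 nM, within a range from 300 nM to 50000 nM, with a fair chance that this assay again reports only a limit.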

Compound 4, half-maximal effective concentration: 575 nM
Estimate against measurement, compound 4: 5.2-fold (0.72 log units) above; the range from low to high includes it.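

In this assay, 3-chlorophenyl in place of benzyl on a sulfonamide nitrogen gives an at least 170-fold lower number from compound 2 to compound 4 (2.24 log units; beyond the scatter), the first single-place step measured in this series, and it lies beyond the scatter. With the rest of the structure shared, the group on this nitrogen alone separates a limit from a measured value. Compound 4 shows that the dichlorobenzamide series can reach a number, 575 nM. Compound 2 remains a limit and not a number, so the true size of this step stays unknown and the printed size is only a bound: the limit of > 100000 nM in this assay, at which 2 of the 4 values shown sit.

The step changes two things together, the chain carbon of benzyl and the chlorine on the ring, so the compounds shown do not tell which of them carries the gain; 3-chlorobenzyl on the same nitrogen would separate the two. As far as these compounds go, how far this nitrogen accepts other groups also stays open, for instance a 2-phenylethyl chain, a pyridyl ring or a carboxylic acid on the aromatic ring.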